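Methoxy in Place of Chloro on a Shared Core

The source may report more compounds than this note shows. Statements on the series, on what has been measured and on what is new or still open speak of the compounds shown alone.

Of the compounds shown here, two have been measured in a functional assay on HCT-116 cells (Homo sapiens); a higher number here means a weaker inhibitor of growth, a lower number a stronger inhibitor of growth. Compound 1 `COc1ccccc1-c1cc(O)c2cc(C)cnc2n1` gives 42700 nM in this assay. Compound 2 `Cc1cc(C)c2c(O)cc(-c3ccc(Cl)cc3)nc2n1` gives 14800 nM, the lowest of the two numbers, and compound 1 stands a step beyond the scatter above it. Compound 3 `COc1ccc(-c2cc(O)c3c(C)cc(C)nc3n2)cc1` differs from compound 2 by a single change: methoxy in place of chloro on an aromatic carbon. Among the measured compounds shown here, no measured pair shows this change, so only an expectation can be given. In this assay a small step toward a higher number, likely within the scatter, is expected: a 1.7-fold higher number from compound 2 to compound 3 (0.23 log units; within the scatter). Compound 3 is therefore estimated at 25000 nM, within a range from 8000 nM to 80000 nM.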

Compound 3, concentration for 50% growth inhibition: 36300 nM
Estimate against measurement, compound 3: 1.5-fold (0.16 log units) below, and the stated range covers the measured number.
By their numbers in this assay, from the lowest: compound 2; then compounds 3 and 1 (each within the scatter of the next).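

Among the compounds shown here, on this aromatic carbon, para to a large group, methoxy in place of chloro gives a 2.5-fold higher number from compound 2 to compound 3 (0.39 log units; beyond the scatter) in this assay, the first change in this set that can be read at a single place. Compounds 1 and 2 differ in more than one place and could not show this. Nothing measured here accounts for the step.

The compounds shown leave open how an amine or a carboxylic acid on this same carbon would compare with chloro. They also leave open whether this step would hold on a different core.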